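The compounds below may be only part of what the source reports. "The series", "measured", "known", "first", "only" and "open" are said of these compounds alone.

Series notes. Compound 1 `Cc1ccc(C(C)C)c(OC(=O)c2cn(-c3ccccc3)nc2-c2cccnc2)c1`, compound 2 `O=C(Oc1ccc2ccccc2c1)c1cn(-c2ccccc2)nc1-c1cccnc1` and compound 3 `Cc1ccc(C(C)C)c(OC(=O)c2cn(-c3ccccc3)nc2-c2ccncc2)c1` have been tested in a functional assay on MDA-MB-231 cells (Homo sapiens) for cytotoxicity, read by MTT assay, with a stated time of 48 h; on this read-out lower numbers stand for stronger inhibition and higher numbers for weaker inhibition; compound 4 `O=C(Oc1ccc2ccccc2c1)c1cn(-c2ccccc2)nc1-c1ccncc1` has not. In this assay compound 1 reaches only the limit of the assay, > 100000 nM. Compound 2 likewise gives a limit, > 100000 nM. Compound 3 also gives a limit, > 100000 nM. The change naphthalen-2-yl in place of 2-isopropyl-5-methylphenyl on an oxygen next to a carbonyl group produces a step that the two limits leave unreadable from compound 1 to compound 2, and the change pyridin-4-yl in place of pyridin-3-yl on an aromatic carbon produces a step that the two limits leave unreadable from compound 1 to compound 3; both steps are unreadable because of the limit of > 100000 nM in this assay, at which 3 of the 3 values shown sit. Compound 4 arises from compound 3 by the same change, (naphthalen-2-yl in place of 2-isopropyl-5-methylphenyl on an oxygen next to a carbonyl group), made on the core of compound 3, which differs from the core of compound 1 as set out already. A step that the limit leaves unreadable from compound 3 to compound 4 is expected for compound 4, resting on the same change having given a step that the two limits leave unreadable from compound 1 to compound 2. Compound 4 is therefore estimated at 150000 nM in this assay, most likely again a limit, within 60000 nM to 400000 nM.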

Compound 4, half-maximal inhibitory concentration: > 100000 nM
Compound 4 gave a limit, no number (the forecaster's own chance of this, stated with the estimate: 85%); the middle value is on the limit's open side.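

No step can be read from compound 3 to compound 4 or from compound 2 to compound 4, because each pair sits at one limit: the limit of > 100000 nM in this assay, at which 4 of the 4 values shown sit.

In this assay the compounds shown leave open whether either change has any effect at all.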